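The compounds below may be only part of what the source reports. "The series", "measured", "known", "first", "only" and "open" are said of these compounds alone.

Compound 1, `Cc1cc(O)cc(-c2nn(CC#N)cc2-c2ccnc(-c3ccc(Oc4ccccc4)cc3)c2)c1`, and compound 2, `COc1cc(C)cc(-c2nn(CC#N)cc2-c2ccnc(-c3ccc(N(C)C)cc3)c2)c1`, were both tested in a functional assay on COLO 205 cells (Homo sapiens) for cytotoxicity, read by sulforhodamine B assay, with a stated time of 48 h, tested at 10 uM; on this read-out higher numbers stand for a weaker effect at the one concentration tested and lower numbers for a stronger effect. In this assay compound 1 gives -96%, while compound 2 gives -61%. Of the two numbers compound 2 holds the higher one, and the gap to compound 1 lies beyond the usual scatter of repeated measurements, so on this read-out compound 2 stands as the weaker of the two.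

The next compound, compound 3, `Cc1cc(O)cc(-c2nn(CC#N)cc2-c2ccnc(-c3ccc(N(C)C)cc3)c2)c1`, is not yet measured. It differs from compound 2 in one place: hydrogen in place of methyl on an oxygen on an aromatic ring. The group that leaves is a methyl, a single carbon without a ring and without any donor or acceptor, and a hydrogen takes its place on the aromatic oxygen, so the methoxy becomes a hydroxy and the 3-methoxy-5-methylphenyl becomes a 3-hydroxy-5-methylphenyl.

Among the measured compounds shown here, no step between two measured compounds shows this change on its own, so there is no direct guide. Compound 3 is expected to come out somewhat lower than compound 2, by a step of a number 14 percentage points lower from compound 2 to compound 3 (beyond the scatter), in the direction of a stronger effect. The estimate for compound 3 in this assay is -75%, within a range from -100% to -45%.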

Compound 3, a percentage reported as activity, at one concentration (the size of the read-out at that concentration, not a potency): -82%
Compound 3: the middle estimate sits 7 percentage points above what was measured; the measured number falls inside the stated range.
By their numbers in this assay, from the lowest: compound 1; then compound 3; then compound 2.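

Among the compounds shown here, with the dimethylamino group held in place, the change from methoxy to hydroxy on the aromatic ring can now be read on its own: in this assay it gives a number 21 percentage points lower from compound 2 to compound 3 (beyond the scatter) and so moves toward a stronger effect, which the earlier compounds could not show because they differ in more than one place. Compound 3 also opens a second comparison, this time with the 3-hydroxy-5-methylphenyl held fixed: dimethylamino in place of phenoxy on an aromatic carbon gives a number 14 percentage points higher from compound 1 to compound 3 (beyond the scatter) and moves toward a weaker effect, so the two changes pull in opposite directions on this read-out. Each step rests on a single pair of compounds, and nothing at hand accounts for either of them.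

What the compounds shown leave open is how an amine or an ethoxy group would read in place of the hydroxy on the aromatic ring, and whether the step from methoxy to hydroxy keeps its size when phenoxy stands in place of dimethylamino. They also leave open how a carboxylic acid or a morpholine on that aromatic carbon would compare with phenoxy and dimethylamino.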